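Halogen placement on the benzyl thiourea head group

The compounds below may be only part of what the source reports. "The series", "measured", "known", "first", "only" and "open" are said of these compounds alone.

Two thioureas share the same pivalate-bearing core and differ in both aryl ends. Compound 1 `COc1cc(CNC(=S)NCC(COC(=O)C(C)(C)C)Cc2ccc(C(C)(C)C)cc2)cc(Cl)c1O` carries a tert-butyl-substituted benzyl arm and a chloro-substituted head group; in an assay on CHO cells for displacement of a labelled ligand from transient receptor potential cation channel subfamily V member 1 (Rattus norvegicus) (on this read-out lower numbers stand for stronger inhibition and higher numbers for weaker inhibition), compound 1 gives 21.3 nM. Compound 2 `COc1cc(CNC(=S)NCC(COC(=O)C(C)(C)C)Cc2ccc(C)c(C)c2)cc(Br)c1O` carries a dimethyl-substituted benzyl arm and a bromo-substituted head group; in this assay compound 2 gives 33.1 nM. Of the two numbers that of compound 2 is the higher one, but the gap to compound 1 lies within the usual scatter, so no order between them can be stated, and no single-point comparison between measured compounds is available for this series.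

Compound 3 `COc1cc(CNC(=S)NCC(COC(=O)C(C)(C)C)Cc2ccc(C)c(C)c2)c(Cl)cc1O` keeps the benzyl arm of compound 2 and changes the head group: 2-chloro-4-hydroxy-5-methoxyphenyl in place of 3-bromo-4-hydroxy-5-methoxyphenyl on a saturated chain carbon bound to an amide-type nitrogen. The halogen thus moves to a different ring position and bromine becomes chlorine at the same time. Within the data shown here, with no measured precedent for such a move here, the expectation is a loss of potency clearly beyond the scatter, as an estimated step of a 3.9-fold higher number from compound 2 to compound 3 (0.59 log units; beyond the scatter). Compound 3 is expected to give 130 nM in this assay, within 40 nM to 450 nM.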

Compound 3, inhibition constant: 24.2 nM
For compound 3 the middle estimate is 5.4-fold (0.73 log units) above the measured one; the measured number lies below the stated range.
By their numbers in this assay, from the lowest: compounds 1, 3 and 2 (each within the scatter of the next).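

With the dimethyl-substituted benzyl arm and the pivalate-bearing core held constant, the change to 2-chloro-4-hydroxy-5-methoxyphenyl in place of 3-bromo-4-hydroxy-5-methoxyphenyl gives a 1.4-fold lower number from compound 2 to compound 3 (0.14 log units; within the scatter) in this assay. Among these compounds, this is the first comparison between compounds that differ in one place, and it shows that on a saturated chain carbon bound to an amide-type nitrogen this head group can be exchanged with no difference that can be told from the scatter. Nothing available on these compounds bears on the reason for this outcome.

The step moves the halogen and exchanges bromine for chlorine at once, so it leaves open whether the two changes are each without consequence or offset one another, and a single change of either kind would be needed to tell these apart. Also open, as far as these compounds go, is how far this tolerance extends beyond the halogens, for instance to a head group carrying a methyl, a nitrile, an amine or a carboxylic acid in the place of the chlorine.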